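Swapping an Amino Acid Arm for an Acyl Sulfonamide

The source may hold more compounds than are shown below. What is called first, only, known or untested is meant among the compounds shown, and "the series" means these compounds.

Of the compounds shown here, two on a shared core have been measured so far. In a functional assay on NCI-H929 cells (Homo sapiens) for antiproliferative activity, with a stated time of 24 h (on this read-out lower numbers stand for stronger inhibition and higher numbers for weaker inhibition), compound 1 `COc1ccc(F)cc1-c1ccnc2[nH]c(C3=CCC(N[C@@H](C(=O)O)C(C)C)CC3)cc12` gives 76 nM, the lower of the two numbers. Compound 2 `COc1ccc(F)cc1-c1ccnc2[nH]c(C3=CCN([C@H]4CC[C@@H](C(=O)O)CC4)CC3)cc12`, which carries a different attached group, gives 97 nM in this assay; the gap between compound 1 and compound 2 lies within the usual scatter, so the two cannot be ranked.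

Compound 3 `COc1ccc(F)cc1-c1ccnc2[nH]c(C3=CCC(C(=O)NS(C)(=O)=O)CC3)cc12` differs from compound 1 in one place: (methylsulfonyl)carbamoyl in place of (1-carboxy-2-methylpropyl)amino on a saturated ring carbon. The group that leaves carries a defined stereocentre and a carboxylic acid; the group that enters is a (methylsulfonyl)carbamoyl group on the same saturated ring carbon. Going by the values given here, no measured pair shows a change of this kind, so there is nothing in the data to calibrate the step.

The step from compound 1 to compound 3 in this assay is therefore expected to be small and toward higher numbers, at a 2.0-fold higher number from compound 1 to compound 3 (0.30 log units; within the scatter), possibly no larger than the scatter. Compound 3 is estimated at 150 nM in this assay, with a range from 40 nM to 600 nM.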

Compound 3, half-maximal inhibitory concentration: 1100 nM
For compound 3 the middle estimate is 7.3-fold (0.87 log units) below the measured one, and the stated range ends below it.
By their numbers in this assay, from the lowest: compounds 1 and 2 (each within the scatter of the next); then compound 3.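

In this assay, putting (methylsulfonyl)carbamoyl in place of (1-carboxy-2-methylpropyl)amino on the saturated ring carbon gives a 14-fold higher number from compound 1 to compound 3 (1.16 log units; beyond the scatter), a large step well beyond the scatter. Going by these compounds alone, this is the first single-place change, and it shows that the read-out is sensitive to which group sits on this carbon, something the two earlier compounds could not show, as they could not be ranked. No measurement shown here explains the rise, so the data record the size and direction of the step but not its cause.

From the compounds shown here alone, the change alters several things at once: the group that leaves brings a ring-bound amine nitrogen, a carboxylic acid, a branched chain and a defined stereocentre, and the group that enters has a sulfur atom and no defined stereocentre, so it remains open which of these differences matters. A plain carboxylic acid or a simple amine on the same saturated ring carbon would help separate these features, and whether either would stay close to compound 1 is an open question.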